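A Halogen Swap on a Chalcone-Bearing Lactone Amide

The compounds below may be only part of what the source reports. "The series", "measured", "known", "first", "only" and "open" are said of these compounds alone.

For the measured compounds named here, compound 1 `O=C(COc1ccc(C(=O)/C=C/c2ccc(Cl)cc2Cl)cc1)N[C@H]1CCOC1=O` is the only compound here that gives a number: in a functional assay on PC-3 cells (Homo sapiens) for antiproliferative activity, read by MTT assay, with a stated time of 72 h (a lower number here means a stronger inhibitor, a higher number a weaker inhibitor), compound 1 gives 8040 nM. Compound 2 `CCCCCCCCCCSC(=S)N[C@H]1CCOC1=O` gives only a limit in this assay, > 64000 nM, as the evidence notes (the limit of > 64000 nM in this assay, at which 1 of the 2 values shown sits). Compound 3 `O=C(COc1ccc(C(=O)/C=C/c2cccc(F)c2)cc1)N[C@H]1CCOC1=O` keeps the shared core of compound 1 and changes one part (3-fluorophenyl in place of 2,4-dichlorophenyl on a double-bonded chain carbon bound to a double-bonded chain carbon). Going by the values given here, no measured pair shows what such a swap does here, so the step of a 1.9-fold higher number from compound 1 to compound 3 (0.27 log units; within the scatter) is expected to be modest, leaning toward weaker inhibition. Compound 3 is therefore estimated at 15000 nM, with a range from 5000 nM to 50000 nM.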

Compound 3, half-maximal inhibitory concentration: 23200 nM
The estimate for compound 3 lay 1.5-fold (0.19 log units) below the measured number; low and high end bracket the measured number.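

For the compounds shown here, putting 3-fluorophenyl in place of 2,4-dichlorophenyl gives the first measured step at this position in this assay: a 2.9-fold higher number from compound 1 to compound 3 (0.46 log units; beyond the scatter). The position therefore responds to the group it carries, and this swap weakens inhibition. No measurement shown here explains the change.

This single step replaces the chlorines with a fluorine and alters their placement together, so the effect of each change remains unseparated. Going by these compounds, how an unsubstituted phenyl, or a phenyl bearing an amine or a carboxylic acid, would compare also stays open.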